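A methyl on the ring amine of compound 1

The source may report more compounds than this note shows. Statements on the series, on what has been measured and on what is new or still open speak of the compounds shown alone.

In a functional assay on DU-145 cells (Homo sapiens) for antiproliferative activity, read by MTT assay (a lower number here means a stronger inhibitor, a higher number a weaker inhibitor), compound 1 (`COc1ccc(-c2nc(N3CCNCC3)nc3ccccc23)c(OC)c1`) gives 50 ug/mL as its value, and compound 3 (`COc1cc(OC)c(-c2nc(N3CCNCC3)nc3ccccc23)c(OC)c1`) stands level with it at 50 ug/mL on the same scale. Together they hold the highest number of the three measured. Compound 4 (`COc1ccc(-c2nc(N3CCN(C)CC3)nc3ccccc23)c(OC)c1`) has methyl in place of hydrogen on an amine nitrogen in a ring, piperazin-1-yl to 4-methylpiperazin-1-yl (methyl in place of hydrogen on an amine nitrogen in a ring). Within the data shown here, the one measured single-place step (no change at the digits printed from compound 1 to compound 3 (within the scatter)) concerns methoxy on an aromatic carbon, so it bears only weakly on this change. Compound 2 (`CN1CCN(c2nc(-n3ccc4ccccc43)c3ccccc3n2)CC1`) carries 4-methylpiperazin-1-yl and gives 20.8 ug/mL as a lower number than compound 1, yet it also differs elsewhere. A small move toward a lower number in this assay is therefore expected, not clearly beyond the scatter (a 1.4-fold lower number from compound 1 to compound 4 (0.15 log units; within the scatter) as the estimated step). Compound 4 is estimated at 35 ug/mL as its expected value, with a range from 17 ug/mL to 60 ug/mL around it.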

Compound 4, half-maximal inhibitory concentration: 50 ug/mL
Estimate against measurement, compound 4: 1.4-fold (0.15 log units) below, and the stated range covers the measured number.
By their numbers in this assay, from the lowest: compound 2; then compounds 1, 3 and 4 (each within the scatter of the next).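

In this assay, methyl in place of hydrogen on the amine nitrogen in the ring gives no change at the digits printed from compound 1 to compound 4 (within the scatter). Among these compounds, this is the first direct reading at this nitrogen, and it shows that the piperazin-1-yl and 4-methylpiperazin-1-yl forms of the core of compound 1 cannot be told apart in this test. Nothing available explains this flat result.

On these data alone, whether a longer chain such as ethyl or benzyl, or a carboxylic acid on an acetyl linker, would move the number at this nitrogen stays open. So does whether methyl would behave the same way on a core carrying other aromatic groups.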